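This account rests on a few compounds, and the source may have more. Where it says the series, first, only, none or still open, it means among the compounds named here.

Measured compounds in this set:

compound 1, `Cc1ccsc1/C=C(/SCc1ccc(F)cc1)C(=O)c1ccc(Br)cc1` — 50000 nM
compound 2, `Cc1ccsc1/C=C(/SCc1ccc(Cl)cc1)C(=O)c1ccc(Br)cc1` — 25000 nM
compound 3, `Cc1ccsc1/C=C(/SCc1ccc(F)cc1)C(=O)c1ccc(Cl)cc1` — 50000 nM

All three were tested in a functional assay on DU-145 cells (Homo sapiens) for inhibition, read by trypan blue exclusion, with a stated time of 96 h; a higher number here means a weaker inhibitor of growth, a lower number a stronger inhibitor of growth. Compound 1 sits level with compound 3 at the digits reported, and together they carry the highest numbers of the three; the step of no change at the digits printed from compound 1 to compound 3 (within the scatter) shows the two cannot be told apart. Compound 2 is the furthest from compound 1, yet even that step, a 2.0-fold lower number from compound 1 to compound 2 (0.30 log units; within the scatter), stays inside the scatter, so the three measured compounds form one flat group.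

The unmeasured compound is compound 4, `COc1ccc(/C=C(/SCc2ccc(F)cc2)C(=O)c2ccc(Br)cc2)cc1`. It differs from compound 1 in a single place: 4-methoxyphenyl in place of 3-methylthiophen-2-yl on a double-bonded chain carbon bound to a double-bonded chain carbon. Neither measured step bears directly on this change, since both concern a halogen swap on an aromatic carbon rather than the group on the double-bonded chain carbon, and both were within the scatter. Among the measured compounds shown here, with no step in the set that moves the number beyond the scatter, the expected step of a 1.3-fold lower number from compound 1 to compound 4 (0.10 log units; within the scatter) is likewise no change beyond the scatter. Compound 4 is therefore estimated at 40000 nM in this assay, within a range from 15000 nM to 100000 nM.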

Compound 4, concentration for 50% growth inhibition: 50000 nM
Compound 4: middle estimate off by 1.3-fold (0.10 log units), on the low side; measured number inside the range.
By their numbers in this assay, from the lowest: compounds 2, 1, 3 and 4 (each within the scatter of the next).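

In this assay, among the compounds shown here, the swap at this place gives no change at the digits printed from compound 1 to compound 4 (within the scatter), the first reading in the set for a change on a double-bonded chain carbon bound to a double-bonded chain carbon rather than a halogen swap on an aromatic carbon. The change is also larger in kind than the earlier ones: a five-membered aromatic ring with a sulfur atom gives way to a six-membered aromatic ring of carbon only, the heavy-atom count goes from 6 to 8, and the hydrogen-bond counts stay the same, yet this assay does not separate the two compounds. No measurement in hand explains this result.

The compounds shown leave open whether any group at this place can move the number out of the flat group, since both groups seen there are aromatic rings with one hydrogen-bond acceptor, and a carboxylic acid, an amine or a longer alkyl chain could read differently. They also leave open whether 4-methoxyphenyl would give the same reading in the setting of compound 2, which carries chloro in place of fluoro.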